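Swapping Methoxy for Acetyl in Compound 3

The source may hold more compounds than are shown below. What is called first, only, known or untested is meant among the compounds shown, and "the series" means these compounds.

In an ADME assay for permeability, using PAMPA (on this read-out lower numbers stand for lower permeability and higher numbers for higher permeability), compound 1 `COc1ccc(Cl)cc1C(=O)Nc1ccc([N+](=O)[O-])cc1Cl` gives 1010 10^-6 cm/s. Compound 2 `COc1ccc(C(=O)Nc2ccc([N+](=O)[O-])cc2Cl)c(O)c1` yields only a limit, < 3 10^-6 cm/s. Compound 3 `COc1ccc(O)c(C(=O)Nc2ccc([N+](=O)[O-])cc2Cl)c1` gives 67.1 10^-6 cm/s, the lower of the two actual numbers, and the gap up to compound 1 lies beyond the scatter. Compound 4 `CC(=O)c1ccc(O)c(C(=O)Nc2ccc([N+](=O)[O-])cc2Cl)c1` carries acetyl in place of methoxy on an aromatic carbon, para to a hydroxy group (acetyl in place of methoxy on an aromatic carbon). For the measured compounds named here, no measured pair isolates this change, so the expectation in this assay stays close to compound 3 at 67.1 10^-6 cm/s, with no shift beyond the scatter. The expected change is small, a 1.3-fold lower number from compound 3 to compound 4 (0.13 log units; within the scatter). For compound 4 the estimated value is 50 10^-6 cm/s, with an expected range from 15 10^-6 cm/s to 170 10^-6 cm/s.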

Compound 4, apparent permeability in the ADME assay: 33.1 10^-6 cm/s
For compound 4 the middle estimate is 1.5-fold (0.18 log units) above the measured one, and the stated range covers the measured number.
By their numbers in the ADME assay, from the lowest: compound 4; then compound 3; then compound 1. At a limit, below all of these: compound 2.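

Acetyl in place of methoxy is the first single change that can be read at this position: in the ADME assay it brings a 2.0-fold lower number from compound 3 to compound 4 (0.31 log units; beyond the scatter), a modest step, while in a physicochemical assay for solubility (a higher number here means a more soluble compound, a lower number a less soluble compound), it brings an at least 23-fold higher number from compound 3 to compound 4 (1.36 log units; beyond the scatter), a large one. In the physicochemical assay compound 3 gives 2.1 ug/mL. In the physicochemical assay compound 4 gives > 49 ug/mL, which is a limit and not a number. At this place, para to a hydroxy group, one change thus moves the two read-outs in opposite directions.

Going by these compounds, whether an amine or a carboxylic acid at this place would do the same stays open. So does whether the swap would give similar steps on another core.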